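Compound 1 to compound 4: chloro to tert-butyl

The source may report more compounds than this note shows. Statements on the series, on what has been measured and on what is new or still open speak of the compounds shown alone.

Measured in a functional assay on HCT-116 cells (Homo sapiens) for inhibition, read by CCK-8 assay, with a stated time of 72 h, tested at 8 uM; a lower number here means less inhibition of growth, a higher number more inhibition of growth at the concentration tested
compound 1 `Nc1ccccc1NC(=O)/C=C/c1ccc(CSc2ccc(Cl)cc2)cc1` gives 3.27%
compound 2 `COc1ccc(SCc2ccc(C(=O)Nc3ccccc3N)cc2)cc1` gives 90.1%
compound 3 `Nc1ccccc1NC(=O)c1ccc(CSCCc2ccccc2)cc1` gives 81.3%

Compound 1 holds the lowest of the three numbers, and compound 2 and compound 3 both lie beyond the scatter above it. Compound 4 `CC(C)(C)c1ccc(SCc2ccc(/C=C/C(=O)Nc3ccccc3N)cc2)cc1` is not yet measured. It differs from compound 1 in one place (tert-butyl in place of chloro on an aromatic carbon), with tert-butyl in place of chloro on an aromatic carbon, para to a large group, so that 4-chlorophenyl becomes 4-(tert-butyl)phenyl.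

For the measured compounds named here, no measured step covers this change. The closest evidence is a swap of the group on sulfur (a number 8.8 percentage points lower from compound 2 to compound 3 (within the scatter)), which stays within the scatter. That step was measured on a core other than the core of compound 1, so it bears on the present change only loosely. One step is thin support, and a rise cannot be excluded, so the range is left wider on the upper side. No step beyond the scatter is expected in this assay for this change. The expected step is a number 6.7 percentage points higher from compound 1 to compound 4 (within the scatter) (an estimate). The estimated value for compound 4 is 10% (expected range 0% to 35%).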

Compound 4, percent growth inhibition at one concentration: 39%
Estimate against measurement, compound 4: 29 percentage points below; measured number outside the range, above it.
By their numbers in this assay, from the lowest: compound 1; then compound 4; then compounds 3 and 2 (each within the scatter of the next).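

In this assay, for the compounds shown here, the change from chloro to tert-butyl gives a number 35.7 percentage points higher from compound 1 to compound 4 (beyond the scatter) and is the first single-place change in this set to go beyond the scatter. The substituent on this aromatic carbon, para to a large group, therefore matters for growth inhibition on the core of compound 1, at least for this pair of groups. Going by these compounds alone, the only earlier step put phenethyl in place of 4-methoxyphenyl on a sulfur, on another core, and gave a number 8.8 percentage points lower from compound 2 to compound 3 (within the scatter) so it could not show how this aromatic position behaves; nothing available explains the size of the new step.

As far as these compounds go, only chloro and tert-butyl can be compared at this position on the core of compound 1, so it remains open whether a dimethylamino group, a carboxylic acid or a longer alkyl chain there would raise growth inhibition further or lower it. From the compounds shown here alone, it also remains open whether the same exchange of chloro for tert-butyl would give a step of similar size on the core of compound 2.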